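Two ether side chains and a cyclopropyl analogue

The compounds below may be only part of what the source reports. "The series", "measured", "known", "first", "only" and "open" are said of these compounds alone.

Compound 1 `CC1CCCC(Oc2cccc3ccc(N)nc23)C1` in an assay on cells with melanin-concentrating hormone receptor 1 (Homo sapiens) as the target, read by radioligand binding (a lower number here means a stronger inhibitor, a higher number a weaker inhibitor), gives 640 nM. Compound 2 `COCC(C)Oc1cccc2ccc(N)nc12` in this assay gives 606 nM.

Compound 2 has the lower of the two numbers, yet its gap to compound 1 lies within the scatter, so the two cannot be told apart. Compound 3 `CC1CC1COc1cccc2ccc(N)nc12` has not been measured; it carries (2-methylcyclopropyl)methyl in place of 1-(methoxymethyl)ethyl on an oxygen on an aromatic ring. Among the compounds with values here, no step between measured compounds guides this change, and the two measured side chains give near-identical results. Compound 3 is therefore expected to show no step beyond the scatter, a 1.0-fold lower number from compound 2 to compound 3 (0.00 log units; within the scatter). Compound 3 is estimated at 600 nM, within 250 nM to 1500 nM.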

Compound 3, half-maximal inhibitory concentration: 1640 nM
Compound 3: the middle estimate sits 2.7-fold (0.44 log units) below what was measured, and the stated range ends below it.
By their numbers in this assay, from the lowest: compounds 2 and 1 (each within the scatter of the next); then compound 3.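

Compound 1 and compound 2 had suggested that the side chain on this oxygen might matter little, but in this assay this change gives a 2.7-fold higher number from compound 2 to compound 3 (0.43 log units; beyond the scatter), so the position does respond to the group it carries. Both groups have 5 heavy atoms, so the step comes without a change in that count, while the hydrogen-bond acceptor of the leaving group is lost and a three-membered ring enters. Nothing at hand bears on the reason for the step.

The compounds shown do not separate the loss of the chain oxygen from the arrival of the ring. As far as these compounds go, how an amine or a carboxylic acid on this side chain would read also remains open.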